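The source may hold more compounds than are shown below. What is called first, only, known or untested is meant among the compounds shown, and "the series" means these compounds.

Compound 2 `O=C(Nc1ccc(-n2ccc3nc(C(=O)NCc4ccccc4)ccc32)cc1)Nc1cccc(Cl)c1Cl` and compound 1 `O=C(Nc1ccc(-n2ccc3nc(C(=O)NCc4ccccc4)ccc32)cc1)Nc1ccc(Cl)c(C(F)(F)F)c1` share one core and differ only in the aryl group on an amide-type nitrogen. In an ADME assay on HS27 cells (Homo sapiens) for cytotoxicity, read by MTT assay (on this read-out lower numbers stand for stronger inhibition and higher numbers for weaker inhibition), compound 2 reaches only the assay limit of > 10000 nM, a bound rather than a number. In this assay compound 1 gives 3000 nM. Compound 3 `O=C(Nc1ccc(-n2ccc3nc(C(=O)NCc4ccccc4)ccc32)cc1)Nc1cccc(C(F)(F)F)c1` arises from compound 2 through the change (3-(trifluoromethyl)phenyl in place of 2,3-dichlorophenyl on an amide-type nitrogen). For the measured compounds named here, the only measured step that bears on this, an at least 3.3-fold higher number from compound 1 to compound 2 (0.52 log units; beyond the scatter), went beyond the scatter when the trifluoromethyl-bearing ring was lost, so a step back down is expected here. Compound 3 is therefore expected to give 5000 nM, between 2000 nM and 15000 nM, a step of an at least 2.0-fold lower number from compound 2 to compound 3 (0.30 log units; that floor lies within the scatter).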

Compound 3, half-maximal inhibitory concentration: > 10000 nM
Compound 3: only a limit was reported; the forecaster's own chance of this, stated with the estimate: 40%; middle value at least 2.0-fold (0.30 log units) away from the limit.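

In this assay compound 3 gives > 10000 nM and this is only a limit. Replacing the chloro with hydrogen while the trifluoromethyl group stays gives an at least 3.3-fold higher number from compound 1 to compound 3 (0.52 log units; beyond the scatter) and so the trifluoromethyl group alone does not keep the readable number of the ring that also carries chloro. The step between the two compounds at the limit, compound 2 and compound 3, cannot be read: the limit of > 10000 nM in this assay, at which 2 of the 3 values shown sit.

Going by these compounds, whether 4-chlorophenyl, with chloro but no trifluoromethyl, would give a readable number remains open. So does the outcome with an amine or a methoxy group on that ring.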